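Swapping the distal aryl ring of a fatty acid receptor agonist

The source may hold more compounds than are shown below. What is called first, only, known or untested is meant among the compounds shown, and "the series" means these compounds.

Within the data shown here, compound 2 `Cn1ccnc1[C@@H](CC(=O)O)c1ccc(OCc2cccc(-c3ccc(Cl)cc3Cl)c2)cc1` holds the lowest of the two numbers so far in an assay on CHO cells for agonist activity at Free fatty acid receptor 1 (Homo sapiens), read by luminescence, with a stated time of 20 s, in the presence of a further agent that is not named here (on this read-out higher numbers stand for an effect only at larger amounts of compound and lower numbers for an effect already at smaller amounts), where compound 2 gives 69 nM. Compound 1 `Cn1ccnc1[C@@H](CC(=O)O)c1ccc(OCc2cccc(-c3ccccc3S(C)(=O)=O)c2)cc1` gives 23000 nM in this assay. Compound 3 `COc1ccc(-c2cccc(COc3ccc([C@H](CC(=O)O)c4nccn4C)cc3)c2)cc1` differs from compound 2 in one place: 4-methoxyphenyl in place of 2,4-dichlorophenyl on an aromatic carbon. Among the measured compounds shown here, the only measured step at this position, a 330-fold lower number from compound 1 to compound 2 (2.52 log units; beyond the scatter), shows that this ring matters greatly, but neither measured compound carries a 4-methoxyphenyl, so its direction is uncertain. A moderate rise is expected, a 7.2-fold higher number from compound 2 to compound 3 (0.86 log units; beyond the scatter), and compound 3 is estimated at 500 nM, within 100 nM to 3000 nM.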

Compound 3, half-maximal effective concentration: 440 nM
Beside the measured number, compound 3's estimate is 1.1-fold (0.06 log units) above it; the measured number falls inside the stated range.
By their numbers in this assay, from the lowest: compound 2; then compound 3; then compound 1.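

In this assay the change to 4-methoxyphenyl gives a 6.4-fold higher number from compound 2 to compound 3 (0.80 log units; beyond the scatter) and, set against the sulfonyl-bearing ring, a 52-fold lower number from compound 1 to compound 3 (1.72 log units; beyond the scatter) as its second step. The three rings therefore give three clearly separated numbers, with compound 3 in the middle. This position works as a graded dial rather than an on-off switch, and a ring without chlorine can still stay far from compound 1.

Nothing available explains why the rings fall in this order. Also open, from the compounds shown here alone, is whether a 4-chlorophenyl ring, or a ring carrying an amine, would match compound 2.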